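Taking the Iodine Off the Weakest of Three

This account rests on a few compounds, and the source may have more. Where it says the series, first, only, none or still open, it means among the compounds named here.

Three compounds share one core and differ only in a single group on an aromatic carbon, para to a large group. In a functional assay on FM3A cells (Mus musculus) for antiproliferative activity (on this read-out lower numbers stand for stronger inhibition and higher numbers for weaker inhibition), compound 1 `COc1cc(C(=O)c2sc(-c3ccc(Br)cc3)cc2N)cc(OC)c1OC`, which carries bromo, gives 150 nM. Compound 2 `COc1cc(C(=O)c2sc(-c3ccc([N+](=O)[O-])cc3)cc2N)cc(OC)c1OC`, which carries nitro, gives 64 nM. Compound 3 `COc1cc(C(=O)c2sc(-c3ccc(I)cc3)cc2N)cc(OC)c1OC`, which carries iodo, gives 420 nM, the highest number of the three and so the weakest inhibition in this small set.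

Compound 4 `COc1cc(C(=O)c2sc(-c3ccccc3)cc2N)cc(OC)c1OC` has not been measured yet. Its change from the iodo compound is hydrogen in place of iodo on an aromatic carbon, which turns 4-iodophenyl into phenyl.

For the measured compounds named here, three measured steps bear on this, all at the same carbon. They are a 2.8-fold higher number from compound 1 to compound 3 (0.45 log units; beyond the scatter), a 6.6-fold higher number from compound 2 to compound 3 (0.82 log units; beyond the scatter) and a 2.3-fold lower number from compound 1 to compound 2 (0.37 log units; beyond the scatter). All are modest, yet beyond the scatter. None of them shows hydrogen at this place, so the guess is a loose one. Both other groups give lower numbers than iodo, so a modest move downward in this assay seems the likeliest outcome.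

The expected step is a 1.8-fold lower number from compound 3 to compound 4 (0.26 log units; within the scatter). Compound 4 is estimated at 230 nM, with an expected range of 80 nM to 650 nM.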

Compound 4, half-maximal inhibitory concentration: 13 nM
Beside the measured number, compound 4's estimate is 18-fold (1.25 log units) above it, outside the stated range (below it).
By their numbers in this assay, from the lowest: compound 4; then compound 2; then compound 1; then compound 3.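

In this assay the iodine comes off in a 32-fold lower number from compound 3 to compound 4 (1.51 log units; beyond the scatter) and this is the largest step seen at this carbon. Hydrogen also does better than the other two groups, with a 4.9-fold lower number from compound 2 to compound 4 (0.69 log units; beyond the scatter) and then a 12-fold lower number from compound 1 to compound 4 (1.06 log units; beyond the scatter) as the steps, so compound 4 gives the strongest inhibition of the four. The earlier compounds shown here only compared one group with another, whereas the plain phenyl reveals that bromo, iodo and nitro all sit on the weaker side of having no added group at this carbon, and even nitro, the best of the three, does not match hydrogen. Nothing in the data shown explains why hydrogen does so much better than these three groups.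

On these data alone, it remains open whether any group at this carbon can equal or improve on hydrogen, since a fluoro, a methyl, a methoxy or an amine could land on either side of the plain phenyl. For the compounds shown here, with only three groups compared against hydrogen, the order seen here cannot be extended to other groups, and these four compounds say nothing about changes elsewhere on the shared core.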